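The source may hold more compounds than are shown below. What is called first, only, known or untested is meant among the compounds shown, and "the series" means these compounds.

Compound 1 `COc1ccc(Nc2cc(C)oc(=O)c2)cc1` reaches only a limit of the assay: in a functional assay on A549 cells (Homo sapiens) for cytotoxicity, read by MTT assay, with a stated time of 72 h (on this read-out higher numbers stand for an effect only at larger amounts of compound and lower numbers for an effect already at smaller amounts), compound 1 gives > 30 uM. Compound 2 `O=c1cc(NC2CCCCC2)cc(-c2ccccc2)o1` gives 9.69 uM, and compound 3 `O=c1cc(Nc2ccc(Br)cc2)cc(-c2ccccc2)o1` gives 0.31 uM. Going by the values given here, the one measured step, a 31-fold lower number from compound 2 to compound 3 (1.49 log units; beyond the scatter), concerns the group on the nitrogen and not the ring carbon that changes here, so it bears on the present change only loosely. Compound 4 `COc1ccc(Nc2cc(C3CCCC3)oc(=O)c2)cc1` differs from compound 1 by cyclopentyl in place of methyl on an aromatic carbon. Compounds 2 and 3 both carry a larger group at that carbon and both give numbers inside the range of this assay. Compound 1 alone sits at the limit (the limit of > 30 uM in this assay, at which 1 of the 3 values shown sits). Compound 4 is therefore expected to yield a number rather than a limit, a step of an at least 3.7-fold lower number from compound 1 to compound 4 (0.57 log units; beyond the scatter), with an estimate of 8 uM between 2 uM and 30 uM.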

Compound 4, concentration for half-maximal effect: 5.42 uM
Estimate against measurement, compound 4: 1.5-fold (0.17 log units) above; low and high end bracket the measured number.
By their numbers in this assay, from the lowest: compound 3; then compounds 4 and 2 (each within the scatter of the next). At a limit, above all of these: compound 1.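

The step gives this position its first direct reading: in this assay, cyclopentyl in place of methyl on the aromatic carbon next to the ring oxygen brings an at least 5.5-fold lower number from compound 1 to compound 4 (0.74 log units; beyond the scatter). Going by these compounds alone, the only earlier step concerned the group on the nitrogen and left this carbon untouched. The value of compound 1 is a limit, and this step is therefore only a bound: the limit of > 30 uM in this assay, at which 1 of the 4 values shown sits.

The compounds shown leave open whether the ring itself matters or whether an open chain such as butyl would serve equally at this carbon. They also leave open how an amine or a carboxylic acid on that group would read.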